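Sulfonamide diamines and pancreatic cancer cell growth

The source may hold more compounds than are shown below. What is called first, only, known or untested is meant among the compounds shown, and "the series" means these compounds.

compound 1, `O=S(=O)(NCCCNCc1ccc(Cl)c(Cl)c1)c1cc(C(F)(F)F)cc(C(F)(F)F)c1`: 2700 nM
compound 2, `O=S(=O)(NCCCCCCNCc1ccc(Br)cc1)c1cc(Cl)cc(Cl)c1`: 12000 nM

Of the compounds shown here, two have been measured in a functional assay on MIA PaCa-2 cells (Homo sapiens) for inhibition, read by MTT assay, with a stated time of 72 h; a higher number here means a weaker inhibitor of growth, a lower number a stronger inhibitor of growth. Compound 2 gives the highest number of the two, and compound 1 gives a lower number than compound 2 by a margin that is beyond the usual scatter. Compound 3, `O=S(=O)(NCCCCCCNCc1ccc(Br)cc1)c1ccccc1Cl`, has not yet been measured. It differs from compound 2 in one place: 2-chlorophenyl in place of 3,5-dichlorophenyl on a sulfonyl sulfur. For the measured compounds named here, no measured pair shows the effect of this change, so only a small step toward a weaker growth inhibitor is expected in this assay, and the expected step is a 1.3-fold higher number from compound 2 to compound 3 (0.12 log units; within the scatter). Compound 3 is estimated at 16000 nM, with a range from 6000 nM to 45000 nM.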

Compound 3, concentration for 50% growth inhibition: 13700 nM
Estimate against measurement, compound 3: 1.2-fold (0.07 log units) above; low and high end bracket the measured number.
By their numbers in this assay, from the lowest: compound 1; then compounds 2 and 3 (each within the scatter of the next).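

In this assay, for the compounds shown here, 2-chlorophenyl in place of 3,5-dichlorophenyl on a sulfonyl sulfur gives a 1.1-fold higher number from compound 2 to compound 3 (0.06 log units; within the scatter), the first measured step at this position. For this one pair, the change from two chlorine atoms to one leaves the two compounds within the scatter of each other. Nothing available explains this result. The compounds shown leave open whether a phenyl group carrying a nitrile or an amine at this position would shift the number beyond the scatter. Compound 1 differs from both compounds in more than one place, so what separates it from them remains unresolved.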